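Halogen swap on the carboxyphenyl ether arm

This account rests on a few compounds, and the source may have more. Where it says the series, first, only, none or still open, it means among the compounds named here.

compound 1 `COc1ccc(C(=O)O)cc1OC[C@@H](C)Oc1ccc(C(=O)CC(C)(C)C)c(O)c1C`: 806 nM
compound 2 `COc1cc(C(=O)O)ccc1OC[C@H](C)COc1ccc(C(=O)CC(C)(C)C)c(O)c1C`: 512 nM
compound 3 `Cc1c(OC[C@@H](C)COc2ccc(C(=O)O)cc2F)ccc(C(=O)CC(C)(C)C)c1O`: 1300 nM

Three compounds of the series have numbers in an assay for positive allosteric modulation of metabotropic glutamate receptor 3 (Rattus norvegicus); a higher number here means that more compound is needed for the effect, a lower number that less compound is needed. Compound 3 gives 1300 nM, the highest of the three. Compound 1 gives 806 nM, and that number stands within the scatter of compound 3, so no order between the two can be claimed. Compound 2 gives 512 nM and lies furthest from compound 3; the single-point step a 2.5-fold higher number from compound 2 to compound 3 (0.40 log units; beyond the scatter) is beyond the scatter, though modest.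

Compound 4 `Cc1c(OC[C@@H](C)COc2ccc(C(=O)O)c(Cl)c2)ccc(C(=O)CC(C)(C)C)c1O` differs from compound 3 in one place: 4-carboxy-3-chlorophenyl in place of 4-carboxy-2-fluorophenyl on an oxygen on a saturated carbon. For the measured compounds named here, the only measured step that touches this end of the molecule is a 2.5-fold higher number from compound 2 to compound 3 (0.40 log units; beyond the scatter), which exchanged a methoxy for a fluoro on the same ring. Going by the values given here, no measured pair exchanges one halogen for another, nor moves a substituent from one ring carbon to another, so the present change has no direct precedent among the three numbers. Given that the one step on this ring was modest, the step of a 1.2-fold lower number from compound 3 to compound 4 (0.07 log units; within the scatter) is expected to be small, most likely within the scatter, with no firm direction. Compound 4 is therefore estimated at 1100 nM in this assay, with a range from 400 nM to 3000 nM.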

Compound 4, half-maximal effective concentration: 860 nM
Compound 4: middle estimate off by 1.3-fold (0.11 log units), on the high side; the range from low to high includes it.
By their numbers in this assay, from the lowest: compounds 2, 1, 4 and 3 (each within the scatter of the next, the first and the last beyond it).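

In this assay, replacing 4-carboxy-2-fluorophenyl with 4-carboxy-3-chlorophenyl on an oxygen on a saturated carbon gives a 1.5-fold lower number from compound 3 to compound 4 (0.18 log units; within the scatter), so on this ring the halogen and its ring place can change together without a step that stands clear of the scatter. For the compounds shown here, of the two steps measured on this ring, only a 2.5-fold higher number from compound 2 to compound 3 (0.40 log units; beyond the scatter) lies beyond the scatter, and that step exchanges methoxy for fluoro, so the series so far shows a readable step for that exchange but none for the exchange of fluoro for chloro with its shift in place. No measurement at hand accounts for the size of the new step, and the two parts of this change cannot be separated from one pair of compounds.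

Still open, from the compounds shown here alone, is whether 4-carboxy-3-fluorophenyl and 4-carboxy-2-chlorophenyl, which would separate the halogen from its place, fall with compound 3 and compound 4 or apart from them. Also open, going by these compounds, is how a bromo or a trifluoromethyl would read in place of the chloro, and whether a tetrazole can stand in for the carboxylic acid on this ring.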